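The source may report more compounds than this note shows. Statements on the series, on what has been measured and on what is new or still open speak of the compounds shown alone.

Within the data shown here, compound 2, `O=C(NN1CCOCC1)c1c(O)c2cccnc2n(-c2ccccc2)c1=O`, stands lowest of the two numbers so far in a functional assay on the whole organism for inhibition, with Rattus norvegicus as the target, read by paw edema, at a dose of 100 mg/kg by the oral route (a higher number here means more inhibition at the dose given (going by the name of the read-out), a lower number less inhibition), where compound 2 gives -8.5%. Among the measured compounds shown here, its nearest neighbour is compound 1, `CN(C)CCNC(=O)c1c(O)c2cccnc2n(-c2ccccc2)c1=O`, which in this assay gives 22.6%; the one step between them, a number 31.1 percentage points lower from compound 1 to compound 2 (beyond the scatter), shows that a change on the amide-type nitrogen can move the number well beyond the scatter. Compound 3, `COc1cccc(NC(=O)c2c(O)c3cccnc3n(-c3ccccc3)c2=O)c1`, differs from compound 2 by 3-methoxyphenyl in place of morpholin-4-yl on an amide-type nitrogen. For the measured compounds named here, no measured step covers an aromatic group entering at this position, so the direction rests only on the size of the one step known. The account therefore expects a step of a number 26.5 percentage points higher from compound 2 to compound 3 (beyond the scatter) in this assay, upward, comparable in size to the step seen before, with wide uncertainty. Compound 3 is accordingly estimated at 18% in this assay, within a range from -12% to 45%.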

Compound 3, a percentage reported as inhibition, in the whole organism at one dose (the size of the read-out at that dose, not a potency): 5.7%
Compound 3: the middle estimate sits 12.3 percentage points above what was measured; low and high end bracket the measured number.
By their numbers in this assay, from the lowest: compound 2; then compound 3; then compound 1.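

In this assay, 3-methoxyphenyl on the amide-type nitrogen gives a number 14.2 percentage points higher from compound 2 to compound 3 (beyond the scatter), yet also a number 16.9 percentage points lower from compound 1 to compound 3 (beyond the scatter), so this aromatic group takes a place in the order above morpholin-4-yl and under 2-(dimethylamino)ethyl. Among these compounds, all three groups at this position now stand apart from one another beyond the scatter, which shows that the number follows the group on this nitrogen across more than the one change seen earlier. No evidence in hand explains this order of the three groups.

As far as these compounds go, what a plain phenyl would give on this nitrogen, and so what the methoxy group adds to the aromatic ring, stays open. Also open, from the compounds shown here alone, is how a longer chain ending in an amine, such as 3-(dimethylamino)propyl, would compare with the 2-(dimethylamino)ethyl chain of compound 1.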